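The source may report more compounds than this note shows. Statements on the series, on what has been measured and on what is new or still open speak of the compounds shown alone.

Compound 1 `CCc1cc2c(cc1C(=O)c1ccc(C(=O)O)cc1)C(C)(C)CCC2(C)C` opens the set. In an assay on CV-1 cells with retinoic acid receptor alpha (Homo sapiens) as the target (on this read-out lower numbers stand for an effect already at smaller amounts and higher numbers for an effect only at larger amounts of compound), compound 1 reaches only the limit of the assay, > 10000 nM. Compound 2 `C=C(c1ccc(C(=O)O)cc1)c1cc2c(cc1C(C)C)C(C)(C)CCC2(C)C` is its close relative. In this assay compound 2 likewise reaches only the limit, > 10000 nM. Compound 2 therefore stands at no number but at the limit of > 10000 nM in this assay, at which 2 of the 2 values shown sit, so the two values show nothing that separates compound 2 from compound 1. Compound 3 `C=C(c1ccc(C(=O)O)cc1)c1cc2c(cc1Br)C(C)(C)CCC2(C)C` differs from compound 2 in one place: bromo in place of isopropyl on an aromatic carbon. Among the compounds with values here, no step between two measured compounds is available here, so the expected size of the step rests on the limits alone. With both measured compounds at the limit, the change is expected to bring no effect beyond the scatter, and the expected step that the limit leaves unreadable from compound 2 to compound 3 is taken as flat. Compound 3 is accordingly estimated at 15000 nM, with a range from 3000 nM to 60000 nM, and most likely again only a limit.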

Compound 3, half-maximal effective concentration: > 10000 nM
Compound 3 was reported as a limit; the forecaster's own chance of this, stated with the estimate: 80%; the middle value is on the limit's open side.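

In this assay compound 3 gives > 10000 nM, which is a limit of the assay and not a number. Within the data shown here, compound 2 sits at a limit too, so no step from it to compound 3 can be read. The compounds shown leave open how bromo and isopropyl compare in this assay.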